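Moving the attachment point on the compound 2 scaffold

The compounds below may be only part of what the source reports. "The series", "measured", "known", "first", "only" and "open" are said of these compounds alone.

Measured in a functional assay on SK-OV-3 cells (Homo sapiens) for antiproliferative activity, read by MTT assay, with a stated time of 72 h (a higher number here means a weaker inhibitor, a lower number a stronger inhibitor), so far
compound 1 `C#Cc1cccc(NC(=O)CCc2cccc3c2B(O)OC3)c1` gives 980 nM
compound 2 `COc1cc(OC)cc(-c2cccc(NC(=O)CCc3cccc4c3B(O)OC4)c2)c1` gives 44 nM
compound 3 `O=C(CCc1cccc2c1B(O)OC2)Nc1cccc(-c2ccc(C(F)(F)F)cc2)c1` gives 500 nM

Compound 2 has the lowest number of the three, and its gaps to compound 1 and compound 3 both lie beyond the scatter. Compound 4 `COc1cc(OC)cc(-c2cccc(NC(=O)CCc3ccc4c(c3)COB4O)c2)c1` has the same atoms as compound 2, joined differently (a group of 10 heavy atoms (7 carbon, 1 boron, 2 oxygen; one five-membered non-aromatic ring with 2 hetero atoms, one six-membered aromatic ring of carbon only) in place of a group of 10 heavy atoms (7 carbon, 1 boron, 2 oxygen; one five-membered non-aromatic ring with 2 hetero atoms, one six-membered aromatic ring of carbon only), on a saturated chain carbon, two bonds along the chain from a carbonyl carbon). The group on the saturated chain carbon, two bonds along the chain from a carbonyl carbon, is what changes. Within the data shown here, no measured step changes that group. The steps of a 22-fold lower number from compound 1 to compound 2 (1.35 log units; beyond the scatter), an 11-fold higher number from compound 2 to compound 3 (1.06 log units; beyond the scatter) and a 2.0-fold lower number from compound 1 to compound 3 (0.29 log units; within the scatter) only exchange ethynyl, 3,5-dimethoxyphenyl and 4-(trifluoromethyl)phenyl on an aromatic carbon, so they give no direct size for this change. They do show that large steps occur in this small series, and an 11-fold higher number from compound 2 to compound 3 (1.06 log units; beyond the scatter) leads away from the lowest number. A higher number is therefore expected, with wide uncertainty. The estimated step in this assay is a 6.8-fold higher number from compound 2 to compound 4 (0.83 log units; beyond the scatter) and is expected to be beyond the scatter. For compound 4 the expected value is 300 nM, with an estimated range of 60 nM to 1500 nM and the measurement still to come.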

Compound 4, half-maximal inhibitory concentration: 93000 nM
Beside the measured number, compound 4's estimate is 310-fold (2.49 log units) below it; the measured number lies above the stated range.
By their numbers in this assay, from the lowest: compound 2; then compounds 3 and 1 (each within the scatter of the next); then compound 4.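

In this assay the isomeric change to the group on the saturated chain carbon, two bonds along the chain from a carbonyl carbon, gives a 2100-fold higher number from compound 2 to compound 4 (3.33 log units; beyond the scatter) with no change in the atoms present. This step exceeds both a 22-fold lower number from compound 1 to compound 2 (1.35 log units; beyond the scatter) and an 11-fold higher number from compound 2 to compound 3 (1.06 log units; beyond the scatter) on the same assay, so how this group is joined can outweigh the exchanges on the aromatic carbon seen earlier. The two groups have identical counts of heavy atoms, hydrogen-bond donors and hydrogen-bond acceptors, so those counts do not separate the pair, and no measurement at hand accounts for the difference.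

As far as these compounds go, whether the same loss appears with ethynyl or 4-(trifluoromethyl)phenyl on the aromatic carbon remains open. Also open, from the compounds shown here alone, is how a longer chain or a carboxylic acid at this place would read.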